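Aryl sulfonyl change on a shared core: antiproliferative notes

The source may report more compounds than this note shows. Statements on the series, on what has been measured and on what is new or still open speak of the compounds shown alone.

Measured so far in a functional assay on SUP-B15 cells (Homo sapiens) for antiproliferative activity, with a stated time of 72 h; a higher number here means that more compound is needed for the effect, a lower number that less compound is needed:
Compound 1, `COc1ccc(-c2cc(=O)c3c(OC)cc(OC)cc3[nH]2)cc1`, gives only a limit: > 62000 nM.
Compound 2, `COc1ccc(-c2cc(=O)c3c(OC)cc(OC)cc3n2Cc2ccccc2)cc1`, gives only a limit: > 34400 nM.
Compound 3, `COc1ccc(-c2cc(=O)c3c(OC)cc(OC)cc3n2S(=O)(=O)c2ccc(C=O)cc2)cc1`, gives only a limit: > 34400 nM.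

Compound 3 therefore stands at the limit of > 34400 nM in this assay, at which 2 of the 3 values shown sit, shared with compound 2, while compound 1 stands at the limit of > 62000 nM in this assay, at which 1 of the 3 values shown sits. The steps between these compounds, a step that the two limits leave unreadable from compound 1 to compound 2, a step that the two limits leave unreadable from compound 1 to compound 3 and a step that the two limits leave unreadable from compound 2 to compound 3, all change the group on the aromatic nitrogen, and none has a readable size.

Compound 4, `COc1ccc(-c2cc(=O)c3c(OC)cc(OC)cc3n2S(=O)(=O)c2cc(F)c(F)c(F)c2)cc1`, keeps the sulfonyl on the aromatic nitrogen and changes the aryl group on it: 3,4,5-trifluorophenyl in place of 4-formylphenyl on a sulfonyl sulfur. Among the compounds with values here, no measured step touches the group on the sulfonyl sulfur, and the three measured steps give no size to lean on. With all three values at limits, compound 4 is expected to stay near the same limit in this assay; the estimate for compound 4 is 40000 nM, between 10000 nM and 150000 nM, a step that the limit leaves unreadable from compound 3 to compound 4 expected to be no more than scatter, if a number is obtained at all.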

Compound 4, half-maximal effective concentration: > 65500 nM
Compound 4 gave a limit, no number; the forecaster's own chance of this, stated with the estimate: 75%; middle value at least 1.6-fold (0.21 log units) away from the limit.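

Within the data shown here, compound 4, like compound 3, gives only a limit in this assay, so no step between compound 3 and compound 4 can be read. The compounds shown leave open whether any group on the aromatic nitrogen or sulfonyl sulfur gives a measurable value in this assay.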